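The source may report more compounds than this note shows. Statements on the series, on what has been measured and on what is new or still open speak of the compounds shown alone.

In a functional assay on MCF7 cells (Homo sapiens) for cytotoxicity, read by MTT assay, with a stated time of 24 h, tested at 1.6 ug/mL (a higher number here means a stronger effect of the compound at the concentration tested, a lower number a weaker effect), the two measured compounds give the following:
Compound 1 `Cn1c(-c2ccc(NC(=O)CSC3=NCCS3)cc2)nc(-c2ccccc2)c1-c1ccccc1` gives 16.2%.
Compound 2 `CCN1CCN(CC(=O)Nc2ccc(-c3nc(-c4ccccc4)c(-c4ccccc4)n3C)cc2)CC1` gives 14.6%.

Compound 2 thus stands beside compound 1 in this assay: the step of a number 1.6 percentage points lower from compound 1 to compound 2 (within the scatter) lies within the scatter. Compound 3 `Cn1c(-c2ccc(NC(=O)CN3CCN(Cc4ccccc4)CC3)cc2)nc(-c2ccccc2)c1-c1ccccc1` differs from compound 2 by phenyl in place of methyl on a saturated chain carbon bound to an amine nitrogen in a ring. Going by the values given here, no measured step alters this part of the molecule; the only guide is that the single measured step at the chain carbon, a number 1.6 percentage points lower from compound 1 to compound 2 (within the scatter), was small. A step of similar size, in either direction or none beyond the scatter, is therefore expected for a number 1.4 percentage points higher from compound 2 to compound 3 (within the scatter). Compound 3 is estimated at 16%, within 5% to 32%.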

Compound 3, a percentage reported as activity, at one concentration (the size of the read-out at that concentration, not a potency): 13.3%
Compound 3: the middle estimate sits 2.7 percentage points above what was measured, within the range that was stated.
By their numbers in this assay, from the lowest: compounds 3, 2 and 1 (each within the scatter of the next).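

Putting phenyl in place of methyl on a saturated chain carbon bound to an amine nitrogen in a ring, which turns ethyl into benzyl, gives a number 1.3 percentage points lower from compound 2 to compound 3 (within the scatter) in this assay. This place on the molecule therefore takes an added aromatic ring without the read-out moving beyond the usual scatter. No measurement available here offers an explanation for this result.

On these data alone, whether a carboxylic acid or a longer chain at this place would shift the number beyond the scatter remains open. A single tested concentration also says nothing about potency.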